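The source may report more compounds than this note shows. Statements on the series, on what has been measured and on what is new or still open speak of the compounds shown alone.

Measured so far:
Compound 1 `O=c1c(-c2ccccc2[N+](=O)[O-])nc2ccccc2n1Cc1ccccc1`: 1000 nM
Compound 2 `O=c1c(-c2cccc(Br)c2)nc2ccccc2n1Cc1ccccc1`: 330 nM

Going by the values given here, in an assay on cells for activation of Cystic fibrosis transmembrane conductance regulator (Homo sapiens), read by fluorescence, with a stated time of 10 min (on this read-out lower numbers stand for an effect already at smaller amounts and higher numbers for an effect only at larger amounts of compound), compound 2 gives the lowest of the two numbers known; the only other compound, compound 1, gives a higher one, and that gap is the single measured step, a 3.0-fold lower number from compound 1 to compound 2 (0.48 log units; beyond the scatter), a modest change that lies beyond the scatter. Compound 3 `O=c1c(-c2ccc3nonc3c2)nc2ccccc2n1Cc1ccccc1` has not yet been measured in this assay. It differs from compound 2 in one place: a group of 9 heavy atoms (6 carbon, 2 nitrogen, 1 oxygen; one five-membered aromatic ring with 3 hetero atoms, one six-membered aromatic ring of carbon only) in place of a group of 7 heavy atoms (6 carbon, 1 bromine; one six-membered aromatic ring of carbon only), on an aromatic carbon, sitting on the shared core next to the ring nitrogen and meta to a benzyl group. Among the compounds with values here, the one measured step shows that swapping the aryl group on this carbon moves the number modestly, but it does not show what a fused ring with three hetero atoms and three acceptors does. Because of a 3.0-fold lower number from compound 1 to compound 2 (0.48 log units; beyond the scatter) only a modest shift is expected for compound 3, with the direction uncertain, so the estimated step is a 1.5-fold higher number from compound 2 to compound 3 (0.18 log units; within the scatter). Compound 3 is therefore expected to give about 500 nM, within a range from 150 nM to 1700 nM.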

Compound 3, half-maximal effective concentration: 18 nM
Beside the measured number, compound 3's estimate is 28-fold (1.44 log units) above it; measured number outside the range, below it.
By their numbers in this assay, from the lowest: compound 3; then compound 2; then compound 1.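

In this assay, the earlier pair showed only a modest move at this aromatic carbon, whereas the group with the fused five-membered ring brings an 18-fold lower number from compound 2 to compound 3 (1.26 log units; beyond the scatter), and against the 2-nitrophenyl group it brings a 56-fold lower number from compound 1 to compound 3 (1.74 log units; beyond the scatter). This position, next to the ring nitrogen and meta to a benzyl group, can therefore respond far more strongly than the swap of one substituted phenyl for another suggested. No measurement here bears on the cause of so large a drop.

With only one such fused group shown, it remains open whether the second ring as such or the hetero atoms within it carry the effect. Also open, going by these compounds, is whether a naphthyl group, with both rings of carbon only, or a phenyl ring carrying an amine or a carboxylic acid, would give a similarly low number.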